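The compounds below may be only part of what the source reports. "The series", "measured", "known", "first", "only" and "open" are said of these compounds alone.

Measured so far:
- compound 1, `CC(=O)O[C@@H]1[C@@H](OC(C)=O)[C@H](O)[C@@H](CO)O[C@H]1NC(=S)NNC(=O)Cn1cnc2ccccc21`, > 100000 nM
- compound 2, `CC(=O)O[C@@H]1[C@@H](OC(C)=O)[C@@H](O)[C@@H](CO)O[C@H]1NC(=S)NNC(=O)Cn1cnc2ccccc21`, > 200000 nM

Both measured compounds share the same atoms and bonds and differ only in configuration as drawn; the step that the two limits leave unreadable from compound 1 to compound 2 in a functional assay on Bel-7402 cells (Homo sapiens) for cytotoxicity, read by MTT assay, with a stated time of 48 h (a lower number here means that less compound is needed, a higher number that more compound is needed for the effect), cannot be sized, since the values at both ends are limits of the assay (the limit of > 100000 nM in this assay, at which 1 of the 2 values shown sits; (the limit of > 200000 nM in this assay, at which 1 of the 2 values shown sits); (the fact that compounds 1 and 2 differ only in the configuration as drawn)). In this assay compound 1 gives only a limit, > 100000 nM. In this assay compound 2 likewise gives only a limit, > 200000 nM. Compound 1 therefore stands at a limit, with no number of its own, and no further value in the series sits at a number either.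

Compound 3, `COc1ccc(C(=O)Nc2nc3ccccc3n2CC(=O)NNC(=S)N[C@@H]2O[C@H](CO)[C@@H](O)[C@H](OC(C)=O)[C@H]2OC(C)=O)cc1`, is to be measured in this assay. It differs from compound 1 by ((4-methoxyphenyl)carbonyl)amino in place of hydrogen on an aromatic carbon. For the measured compounds named here, no measured step bears on this change: the only step available runs between two limits and concerns configuration alone, not a group added to the shared core. No direction and no size beyond the scatter can be taken from the data for this change, so the step expected for compound 3 is estimated as a number no higher from compound 1 to compound 3 (the limit leaves the size open), with a further limit considered the most likely outcome. Compound 3 is estimated at 100000 nM, within 30000 nM to 300000 nM.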

Compound 3, half-maximal effective concentration: 22800 nM
Compound 3: the middle estimate sits 4.4-fold (0.64 log units) above what was measured, outside the stated range (below it).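

Replacing hydrogen with ((4-methoxyphenyl)carbonyl)amino on the aromatic carbon between two ring nitrogen atoms gives, in this assay, an at least 4.3-fold lower number from compound 1 to compound 3 (0.64 log units; beyond the scatter), which makes this position the first place in the series where a change gives a readable step and a value that is not a limit. Compound 1 gives only a limit, > 100000 nM, so the step is a minimum. Nothing measured here gives a reason for this step.

An amine or an unsubstituted benzoylamino group at the same position would show whether the whole group is needed or only part of it. From the compounds shown here alone, the step between compound 1 and compound 2 cannot be read, so whether configuration matters once this group is present also stays open.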